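A few compounds are considered here, and "the series" means these few. Any claim that something is new, unique, unknown or untested is made for them only; others in the source may bear on it.

Working notes on the sulfonyl series

The series is followed in a functional assay (Cavia porcellus) with sulfonylurea receptors; K-ATP channels (Homo sapiens) as the target; a lower number here means a stronger inhibitor, a higher number a weaker inhibitor. Compound 1 `CN(c1ccccc1)S(=O)(=O)c1ccc(NC(=O)C(C)(O)C(F)(F)F)cc1` carries a methyl(phenyl)amino group on the sulfonyl sulfur; in this assay compound 1 gives 2000 nM. Compound 2 `CC(O)(C(=O)Nc1ccc(S(=O)(=O)c2ccccn2)cc1)C(F)(F)F` has pyridin-2-yl in that place, and in this assay compound 2 gives 600 nM. Within the data shown here, the one measured step, a 3.3-fold lower number from compound 1 to compound 2 (0.52 log units; beyond the scatter), is modest but beyond the scatter. Compound 2 thus stands with the lowest number of the two measured, the next being compound 1.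

Compound 3 `CC(O)(C(=O)Nc1ccc(S(=O)(=O)c2cccnc2)cc1)C(F)(F)F` is the next point. Its difference from compound 2 is pyridin-3-yl in place of pyridin-2-yl on a sulfonyl sulfur; the two have the same atoms, joined differently, so the single ring nitrogen moves within the six-membered aromatic ring on the sulfonyl sulfur. Among the measured compounds shown here, no measured step bears on this move directly: the only step so far, from compound 1 to compound 2, exchanges the whole group rather than the ring position of the nitrogen. The size of the step in this assay for compound 3 is therefore uncertain; a change within or only just beyond the scatter is the expected outcome, with a slightly higher number considered somewhat more likely than a lower one, expressed as a 1.3-fold higher number from compound 2 to compound 3 (0.12 log units; within the scatter). For compound 3 the estimated value in this assay is 800 nM, expected to lie between 300 nM and 2400 nM.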

Compound 3, half-maximal inhibitory concentration: 3500 nM
Estimate against measurement, compound 3: 4.4-fold (0.64 log units) below; the measured number lies above the stated range.
By their numbers in this assay, from the lowest: compound 2; then compounds 1 and 3 (each within the scatter of the next).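

In this assay the site on the sulfonyl sulfur proves sensitive to where the ring nitrogen lies, not only to which group is attached: a 5.8-fold higher number from compound 2 to compound 3 (0.77 log units; beyond the scatter) is beyond the scatter, although pyridin-2-yl and pyridin-3-yl have the same heavy-atom, donor and acceptor counts. The other new step, a 1.8-fold higher number from compound 1 to compound 3 (0.24 log units; within the scatter), stays within the scatter, so pyridin-3-yl and methyl(phenyl)amino are not told apart here, and of the three groups on the sulfonyl sulfur only pyridin-2-yl, in compound 2, stands apart from both others. No supporting measurement bears on why moving the ring nitrogen has this effect.

From the compounds shown here alone, whether pyridin-4-yl or a plain phenyl group on the sulfonyl sulfur would fall nearer compound 2 or nearer compound 3 remains open, so the pyridin-2-yl result cannot yet be read as a trend across ring positions. Also open, going by these compounds, is whether the gap between pyridin-2-yl and pyridin-3-yl persists when a further group, such as an amine or a methoxy group, is carried on the pyridine ring.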